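The source may report more compounds than this note shows. Statements on the series, on what has been measured and on what is new or still open speak of the compounds shown alone.

Compound 3 `COC(=O)c1cc(-c2cccc(NC(=O)c3ccc(/C=C/C(=O)c4ccccc4O)cc3)c2)on1` is the starting point here, yet in an ADME assay on Vero cells (Chlorocebus sabaeus) for cytotoxicity, read by MTT assay, with a stated time of 72 h (a higher number here means that more compound is tolerated, a lower number that less compound is tolerated), compound 3 is recorded only as "not determined" (no result reported), so it cannot be placed against the other members of the series. Compound 1 `COC(=O)c1cc(-c2cccc(NC(=O)c3ccc(/C=C/C(=O)c4cccc(Cl)c4)cc3)c2)on1` is the closest measured relative, and in this assay compound 1 gives only a limit of > 2.5 ug/mL rather than a number. Compound 2 `COC(=O)c1cc(-c2cccc(NC(=O)c3ccc(OCc4ccc(Cl)cc4)cc3)c2)on1` also stops at a limit, in this case > 80 ug/mL. The step that the two limits leave unreadable from compound 1 to compound 2 is therefore unreadable, because the limit of > 2.5 ug/mL in this assay, at which 1 of the 3 values shown sits, and the limit of > 80 ug/mL in this assay, at which 1 of the 3 values shown sits, cap both ends of it. Compound 4 `COC(=O)c1cc(-c2cccc(NC(=O)c3ccc(/C=C/C(=O)c4ccccc4Cl)cc3)c2)on1` differs from compound 3 by chloro in place of hydroxy on an aromatic carbon. Among the measured compounds shown here, no measured step in this set repeats that exchange, and compound 3 itself carries no value, so there is no direct anchor for the size or direction of the change. What remains are the two limits of compound 1 and compound 2, which only bound where a value might fall. Compound 4 is therefore estimated to give about 20 ug/mL, expected to lie between 4 ug/mL and 80 ug/mL.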

Compound 4, half-maximal cytotoxic concentration: > 25 ug/mL
Compound 4: no number, only a limit; the forecaster's own chance of this, stated with the estimate: 50%; middle value at least 1.2-fold (0.09 log units) from the limit.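

In this assay compound 4 gives only a limit, > 25 ug/mL. Compound 1 and compound 2 also stop at limits, so neither step to compound 4 can be read. Still open, as far as these compounds go, are the actual values of compound 1, compound 2 and compound 4, and what chloro in place of hydroxy does here.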